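This account rests on a few compounds, and the source may have more. Where it says the series, first, only, none or still open, it means among the compounds named here.

Of the compounds shown here, two have been measured in a functional assay on a cell-free system (plasma) for agonist activity at thromboxane A2 receptor (Homo sapiens); a higher number here means a weaker inhibitor, a lower number a stronger inhibitor. Compound 1, with the structure `O=C(O)CCC/C=C1\C[C@H]2CC[C@H](/C=N/NC(=O)Nc3ccc(Cl)c(Cl)c3)[C@H]2C1`, gives 9000 nM in this assay. Compound 2, with the structure `O=C(O)CCC/C=C1/C[C@H]2CC[C@H](/C=N/NC(=O)Nc3ccc([N+](=O)[O-])cc3)[C@H]2C1`, gives 580 nM in this assay, the lower of the two numbers; compound 1 stands at a higher number, and the gap between them lies beyond the usual scatter. Since compound 1 and compound 2 differ in more than one place, the two values alone do not tell how much of that gap belongs to the aryl group and how much to the geometry of the exocyclic double bond.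

Compound 3, with the structure `O=C(O)CCC/C=C1\C[C@H]2CC[C@H](/C=N/NC(=O)Nc3ccc([N+](=O)[O-])cc3)[C@H]2C1`, is the next compound. It differs from compound 2 in this way: the two compounds have the same atoms and bonds and differ only in configuration as drawn: 1 of 5 stereo elements differ; a double bond is drawn Z in compound 2 and E in compound 3. For the measured compounds named here, no measured pair isolates this change, so its size is open. Going by the values given here, for compound 3 a weakening beyond the scatter is expected, though a smaller one than that whole gap, because compound 1, the only other compound measured and the one drawn with the same double bond geometry, gives 9000 nM. Compound 3 is estimated at 1800 nM in this assay, within a range from 400 nM to 8000 nM, which would mean an expected step of a 3.1-fold higher number from compound 2 to compound 3 (0.49 log units; beyond the scatter).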

Compound 3, half-maximal inhibitory concentration: 1700 nM
Estimate against measurement, compound 3: 1.1-fold (0.02 log units) above; low and high end bracket the measured number.
By their numbers in this assay, from the lowest: compound 2; then compound 3; then compound 1.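

In this assay, the geometry of the exocyclic double bond now has a size of its own: the step of a 2.9-fold higher number from compound 2 to compound 3 (0.47 log units; beyond the scatter) lies beyond the scatter, and the form drawn Z gives the lower number. This step can be assigned to that double bond alone, because of a single fact: the fact that compounds 2 and 3 differ only in the configuration as drawn. For the compounds shown here, the aryl group can also be read separately for the first time, at the E geometry, where the step of a 5.3-fold lower number from compound 1 to compound 3 (0.72 log units; beyond the scatter) accompanies 4-nitrophenyl in place of 3,4-dichlorophenyl, so the earlier gap between compound 1 and compound 2 now resolves into two single changes, each beyond the scatter.

The compounds shown leave open whether the Z geometry would give a lower number with 3,4-dichlorophenyl as well, and therefore whether the two changes simply add or depend on each other. They also leave open how a plain phenyl group would compare with these two aryl groups, and what an ester in place of the carboxylic acid would do to the number at either geometry.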